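The source may hold more compounds than are shown below. What is called first, only, known or untested is meant among the compounds shown, and "the series" means these compounds.

Compound 1 `CC(CCCCOc1ccccc1CN(C)C(=O)c1ccc(-c2ccco2)cc1)C(=O)O`: 2.8 h
Compound 2 `C[C@H](CCCOc1ccccc1CN(C)C(=O)c1ccc(-c2ccco2)cc1)CC(=O)O`: 3.9 h
Compound 3 `CN(Cc1ccccc1OCCC[C@@H]1C[C@H]1C(=O)O)C(=O)c1ccc(-c2ccco2)cc1`: 3.5 h

These three compounds were measured in an ADME assay on the whole organism (strain CD-1) for metabolic stability, with Mus musculus as the target, at a dose of 3 mg/kg by the intravenous route; a higher number here means that the compound lasts longer, a lower number that the compound disappears faster. Compound 3, at 3.5 h, lies within the scatter of both other compounds, so the numbers do not separate it from either one.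

Compound 4 `C/C(=C\COc1ccccc1CN(C)C(=O)c1ccc(-c2ccco2)cc1)CCC(=O)O` has the same atoms as compound 3, joined differently: 4-carboxy-2-methylbut-1-en-1-yl in place of 2-(2-carboxycyclopropyl)ethyl on a saturated chain carbon bound to an oxygen on an aromatic ring. In words, 4-carboxy-2-methylbut-1-en-1-yl stands in place of 2-(2-carboxycyclopropyl)ethyl on a saturated chain carbon bound to an oxygen on an aromatic ring.

Among the compounds with values here, three measured steps bear on this, since each exchanges the carboxy-bearing end of the chain: a 1.4-fold higher number from compound 1 to compound 2 (0.14 log units; within the scatter), a 1.3-fold higher number from compound 1 to compound 3 (0.10 log units; within the scatter) and a 1.1-fold lower number from compound 2 to compound 3 (0.05 log units; within the scatter). All three are small and stay within the scatter. Within the data shown here, none of them is the same change, however, and no measured compound has a double bond in this chain, so they offer only indirect guidance.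

In this assay, the expectation is therefore no change beyond the scatter, in neither direction. The estimated result is a 1.1-fold lower number from compound 3 to compound 4 (0.04 log units; within the scatter). For compound 4 the estimated value is 3.2 h, with an expected range of 1.8 h to 5.5 h.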

Compound 4, half-life: 2.3 h
Beside the measured number, compound 4's estimate is 1.4-fold (0.14 log units) above it; the measured number falls inside the stated range.
By their numbers in this assay, from the lowest: compounds 4, 1, 3 and 2 (each within the scatter of the next).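

In this assay the open-chain 4-carboxy-2-methylbut-1-en-1-yl in place of 2-(2-carboxycyclopropyl)ethyl gives a 1.5-fold lower number from compound 3 to compound 4 (0.18 log units; within the scatter) and stays within the scatter, so this exchange of a ring for a double bond does not separate the two compounds. Within the data shown here, the other two comparisons agree, with a 1.7-fold lower number from compound 2 to compound 4 (0.23 log units; within the scatter) and with a 1.2-fold lower number from compound 1 to compound 4 (0.09 log units; within the scatter) as well, so the four chains, saturated, ring-bearing or unsaturated, give half-lives that these numbers cannot tell apart, and this holds even though compound 4 is the first of them with a carbon-carbon double bond in the chain. Nothing among the data shown explains why the number for compound 4 falls where it does.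

As far as these compounds go, all four compounds carry a carboxylic acid, so it remains open how the half-life would respond to a tetrazole or a primary amide in its place, or to a shorter chain on the same oxygen. Also open, from the compounds shown here alone, is how the other geometry of the double bond, or the mirror-image form of the cyclopropane ring in compound 3, would read in this measurement.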